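Expected lipophilicity after losing the carbamoylcyclohexyl group

The compounds below may be only part of what the source reports. "The series", "measured", "known", "first", "only" and "open" are said of these compounds alone.

- compound 1 `CC(=O)N1CCN([C@H]2CC[C@H](Nc3ncnn4ccc([C@H]5CC[C@H](C(N)=O)CC5)c34)CC2)CC1`: 1.4 
- compound 2 `CN(C)[C@H]1CC[C@H](Nc2ncnn3ccc([C@H]4CC[C@@H](C(N)=O)CC4)c23)CC1`: 0.1 
- compound 3 `COC(=O)N1CCN([C@H]2CC[C@H](Nc3ncnn4ccc(C(C)C)c34)CC2)CC1`: 3.3 

In a physicochemical assay for lipophilicity, using the shake flask method, at pH 7.4 (on this read-out higher numbers stand for higher lipophilicity and lower numbers for lower lipophilicity), compound 2 gives 0.1 and is the lowest of the three, clearly apart from both others. The next structure, compound 4 `CN(C)[C@H]1CC[C@H](Nc2ncnn3cccc23)CC1`, follows from compound 2 by one change (hydrogen in place of 4-carbamoylcyclohexyl on an aromatic carbon): hydrogen in place of 4-carbamoylcyclohexyl on an aromatic carbon of a five-membered aromatic ring with 1 nitrogen.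

Going by the values given here, no two measured compounds differ in one place only, so no measured step guides this change. Compound 3 lacks the 4-carbamoylcyclohexyl group and still gives 3.3 as the highest value, but it also differs from compound 2 elsewhere, so its number does not settle the direction. Compound 1 carries the group and gives 1.4 with a different substituent elsewhere, which again isolates nothing. A small downward shift is the working expectation, close to the usual scatter and not clearly beyond it. The expected change in this assay is a number 0.30 log units lower from compound 2 to compound 4 (within the scatter) on this reasoning, with real uncertainty about its sign. The estimated value for compound 4 is -0.2 with an expected range from -0.9 to 0.5 in this read-out.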

Compound 4, distribution coefficient: 0
Estimate against measurement, compound 4: 0.20 log units below; low and high end bracket the measured number.
By their numbers in this assay, from the lowest: compounds 4 and 2 (each within the scatter of the next); then compound 1; then compound 3.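

This gives the series its first step that differs in one place only: in this assay, hydrogen in place of 4-carbamoylcyclohexyl on an aromatic carbon of a five-membered aromatic ring with 1 nitrogen gives a number 0.10 log units lower from compound 2 to compound 4 (within the scatter). The earlier compounds shown here could not isolate this position, as each pair among them also differs elsewhere, whereas here the whole 4-carbamoylcyclohexyl group, with its six-membered ring of carbon only and its 2 defined stereocentres, goes and the read-out does not separate the two compounds. On this shared background, then, the position takes either the group or hydrogen with no difference beyond the usual scatter, though nothing available explains this result.

Going by these compounds alone, open is how a carboxylic acid, a primary amine or a longer alkyl chain on this same aromatic carbon would read in this assay, as the single step spans only the 4-carbamoylcyclohexyl group and hydrogen. Also open, on these data alone, is whether the same exchange gives a step of this size on the background of compound 1, which carries the group with a different substituent elsewhere.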